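The source may hold more compounds than are shown below. What is called first, only, known or untested is meant among the compounds shown, and "the series" means these compounds.

Measured so far:
- compound 1, `CCO/C(O)=C1\C(COCCNc2n[nH]c(N)n2)=NC(C)=C(C(=O)OC)C1c1cccc(Cl)c1Cl`: 6.31 nM
- compound 2, `CCO/C(O)=C1\C(COCC/N=C(/N)S)=NC(C)=C(C(=O)OC)C1c1cccc(Cl)c1Cl`: 1 nM
- compound 3, `CCO/C(O)=C1\C(COCCNc2nccc(O)n2)=NC(C)=C(C(=O)OC)C1c1cccc(Cl)c1Cl`: 2.51 nM

All three were tested in a functional assay (aorta) with Rattus norvegicus as the target; on this read-out lower numbers stand for stronger inhibition and higher numbers for weaker inhibition. Compound 1 stands highest of the three numbers: compound 3 is nearest, and compound 2 is furthest away. Compound 1 and compound 4, `CCO/C(O)=C1\C(COCCNc2nccnc2NC)=NC(C)=C(C(=O)OC)C1c1cccc(Cl)c1Cl`, share the same core and differ in one place: 3-(methylamino)pyrazin-2-yl in place of 5-amino-1H-1,2,4-triazol-3-yl on an amine nitrogen.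

For the measured compounds named here, two measured steps bear on this change, since both also replace the same triazolyl group. The step of a 6.3-fold lower number from compound 1 to compound 2 (0.80 log units; beyond the scatter), which puts in a group with no ring, is the larger of the two. The step of a 2.5-fold lower number from compound 1 to compound 3 (0.40 log units; beyond the scatter), which puts in a six-membered aromatic ring with two hetero atoms, is the closer analogy. The group entering compound 4 is also a six-membered aromatic ring with two hetero atoms carrying a single hydrogen-bond donor. A modest step downward in this assay is therefore expected for compound 4, of the size seen with compound 3: a 2.5-fold lower number from compound 1 to compound 4 (0.40 log units; beyond the scatter). The expected value for compound 4 is 2.5 nM, within a range from 1 nM to 6.3 nM.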

Compound 4, half-maximal inhibitory concentration: 5.01 nM
Compound 4: the middle estimate sits 2.0-fold (0.30 log units) below what was measured, within the range that was stated.
By their numbers in this assay, from the lowest: compound 2; then compounds 3, 4 and 1 (each within the scatter of the next, the first and the last beyond it).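

In this assay, putting 3-(methylamino)pyrazin-2-yl in place of 5-amino-1H-1,2,4-triazol-3-yl on the amine nitrogen gives a 1.3-fold lower number from compound 1 to compound 4 (0.10 log units; within the scatter), so this five-membered ring and this six-membered ring cannot be told apart at this position. The two six-membered rings cannot be separated either, as the change of ring gives a 2.0-fold higher number from compound 3 to compound 4 (0.30 log units; within the scatter), while the group with no ring stays clearly apart from the methylamino pyrazine, with a 5.0-fold higher number from compound 2 to compound 4 (0.70 log units; beyond the scatter). No measurement here explains why these groups compare as they do.

The compounds shown leave open whether a plain phenyl ring or a simple acetyl group on this amine nitrogen would fall with the ring-bearing compounds or with the ring-free one. They also leave open what a longer chain in place of the ethyl chain would do.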